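The source may report more compounds than this note shows. Statements on the series, on what has been measured and on what is new or still open speak of the compounds shown alone.

Compound 1 `C/C=C/C(=O)N(Cc1cccc(O)c1)c1cc(OC)c(OC)c(OC)c1`: 14100 nM
Compound 2 `COc1ccc(CNc2cc(OC)c(OC)c(OC)c2)cc1C`: 56800 nM
Compound 3 `C/C=C/C(=O)N(Cc1ccc(OC)c(C)c1)c1cc(OC)c(OC)c(OC)c1`: 14500 nM

All three numbers come from a functional assay on MGC-803 cells (Homo sapiens) for inhibition, read by MTT assay, with a stated time of 48 h; a higher number here means a weaker inhibitor, a lower number a stronger inhibitor. For the measured compounds named here, compound 3 stands second highest of the three; its number sits within the scatter of compound 1, and the only step beyond the scatter is a 3.9-fold lower number from compound 2 to compound 3 (0.59 log units; beyond the scatter), which concerns the group on the amide-type nitrogen and not the benzyl ring.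

Compound 4 `C/C=C/C(=O)N(Cc1ccc(OC)c(N)c1)c1cc(OC)c(OC)c(OC)c1` differs from compound 3 by amino in place of methyl on an aromatic carbon. The step that bears on this change is a 1.0-fold higher number from compound 1 to compound 3 (0.01 log units; within the scatter), which swapped substituents on the same ring and stayed within the scatter. A single substituent exchange on this ring is therefore expected to give no step beyond the scatter, a 1.0-fold lower number from compound 3 to compound 4 (0.02 log units; within the scatter). Compound 4 is estimated at 14000 nM, with a range from 6500 nM to 30000 nM.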

Compound 4, half-maximal inhibitory concentration: 150 nM
Compound 4: middle estimate off by 93-fold (1.97 log units), on the high side, outside the stated range (below it).
By their numbers in this assay, from the lowest: compound 4; then compounds 1 and 3 (each within the scatter of the next); then compound 2.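

Amino in place of methyl, ortho to a methoxy group, gives a 97-fold lower number from compound 3 to compound 4 (1.99 log units; beyond the scatter) in this assay, whereas compound 1 and compound 3, with different substituents on this ring, stand within the scatter of each other. So this ring is not indifferent to its substituents, and a single heavy-atom exchange at this carbon is enough to separate compound 4 from compound 3. The 3-amino-4-methoxyphenyl group also stands apart from 3-hydroxyphenyl, with a 94-fold lower number from compound 1 to compound 4 (1.97 log units; beyond the scatter) in this assay and no measurement at hand explains these steps.

Going by these compounds, whether the step is specific to a primary amine remains open, since a hydroxyl, a dimethylamino group or an acetamide at this carbon would be needed to tell. Also open, on these data alone, is whether the amino group keeps this effect without the methoxy group.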